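Carboxy-terminated chain extension on the aryloxy-alkyl series

A few compounds are considered here, and "the series" means these few. Any claim that something is new, unique, unknown or untested is made for them only; others in the source may bear on it.

Measured compounds:
compound 1, `NCCCCCCOc1ccc2c(=O)c(-c3ccc(O)cc3)coc2c1`, 100 nM in an assay (Cricetulus griseus) for inhibition of aldehyde dehydrogenase, mitochondrial (Homo sapiens); on this read-out lower numbers stand for stronger inhibition and higher numbers for weaker inhibition
compound 2, `O=C(O)CCCCCCOc1ccc2c(=O)c(-c3ccc(O)cc3)coc2c1`, 50 nM
compound 3, `O=c1c(-c2ccc(O)cc2)coc2cc(OCCCCCCO)ccc12`, 120 nM

Compound 3 gives the highest number of the three in this assay. The step of a 1.2-fold higher number from compound 1 to compound 3 (0.08 log units; within the scatter) stays within the scatter, so no order between these two can be claimed. The step of a 2.4-fold higher number from compound 2 to compound 3 (0.38 log units; beyond the scatter) is a modest one beyond the scatter, the only resolved difference in the set. Compound 2 and compound 1 are separated by a 2.0-fold lower number from compound 1 to compound 2 (0.30 log units; within the scatter).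

The next compound is compound 4, `O=C(O)CCCCCCCCCCCCCCCOc1ccc2c(=O)c(-c3ccc(O)cc3)coc2c1`. Its change from compound 3 is 9-carboxynonyl in place of hydroxy on a saturated chain carbon, six bonds along the chain from an oxygen on an aromatic ring. Among the measured compounds shown here, the only measured step that bears on this change is the one between compound 2 and compound 3, where carboxy in place of hydroxy on the chain end gave the lower number; the reverse reading of a 2.4-fold higher number from compound 2 to compound 3 (0.38 log units; beyond the scatter) suggests a carboxy terminus lowers the number modestly. For the measured compounds named here, no measured compound carries a chain of this length, so the size of that part of the change is unknown and widens the range.

Compound 4 is therefore expected to sit a little below compound 3, with the step of a 2.0-fold lower number from compound 3 to compound 4 (0.30 log units; within the scatter). The estimate for compound 4 in this assay is 60 nM, within a range from 20 nM to 200 nM.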

Compound 4, half-maximal inhibitory concentration: > 9000 nM
Compound 4 gave a limit, no number (the forecaster's own chance of this, stated with the estimate: 5%); at least 150-fold (2.17 log units) between middle value and limit.
By their numbers in this assay, from the lowest: compounds 2, 1 and 3 (each within the scatter of the next, the first and the last beyond it). At a limit, above all of these: compound 4.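

Compound 4 gives a limit and not a number in this assay: the limit of > 9000 nM in this assay, at which 1 of the 4 values shown sits. Measured against that limit, the steps read an at least 75-fold higher number from compound 3 to compound 4 (1.87 log units; beyond the scatter), an at least 90-fold higher number from compound 1 to compound 4 (1.95 log units; beyond the scatter) and an at least 180-fold higher number from compound 2 to compound 4 (2.25 log units; beyond the scatter), all large and all beyond the scatter, whereas exchanging the end group among amino, hydroxy and carboxy on the shorter chain gave at most a modest step. Compound 2 and compound 4 both end in a carboxy group, so in this pair the large step goes with the 9-carboxynonyl extension at this chain carbon and not with the end group, a dependence on chain length that compounds 1, 2 and 3, all sharing one chain length, could not show.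

The compounds shown leave open where between these two chain lengths the number begins to climb, which a carboxylic acid on a chain of intermediate length would address. On these data alone, whether the same extension is as poorly received with another end group also remains open, and a longer chain ending in an amine or in a hydroxy group would test that.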